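Shortening an Ethoxy on a Thiazolidinedione Series

The source may hold more compounds than are shown below. What is called first, only, known or untested is meant among the compounds shown, and "the series" means these compounds.

Measured compounds:
- compound 1 `CCOc1cc(/C=C2\SC(=O)NC2=O)ccc1OCC1(C)CCc2c(C)c(OCC=C(C)C)c(C)c(C)c2O1`: 84%
- compound 2 `C=CCOc1c(C)c(C)c2c(c1C)CCC(C)(COc1ccc(/C=C3\SC(=O)NC3=O)cc1OCC)O2`: 87%
- compound 3 `Cc1c(C)c2c(c(C)c1OCc1ccccc1)CCC(C)(COc1ccc(/C=C3\SC(=O)NC3=O)cc1)O2`: 42%

In a functional assay on MCF7 cells (Homo sapiens), tested at 5 uM (on this read-out lower numbers stand for a stronger effect and higher numbers for a weaker effect at the one concentration tested), compound 1 gives 84%, the second highest of the three numbers. Among the compounds with values here, its nearest neighbour is compound 2, where the step of a number 3 percentage points higher from compound 1 to compound 2 (within the scatter) lies within the scatter; the furthest is compound 3, whose value stands well lower, although compound 3 differs from compound 1 in more than one place and no single step links the two.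

Compound 4 `COc1cc(/C=C2\SC(=O)NC2=O)ccc1OCC1(C)CCc2c(C)c(OCC=C(C)C)c(C)c(C)c2O1` is not yet measured. It differs from compound 1 by hydrogen in place of methyl on a saturated chain carbon bound to an oxygen on an aromatic ring. Within the data shown here, none of the measured steps touches this position: the only single-place step, from compound 1 to compound 2, changes a group elsewhere and stays within the scatter. Among the measured compounds shown here, with no direct precedent, and a change that leaves and enters so little, the expectation is of no step beyond the scatter in this assay.

Compound 4 is therefore estimated at 82%, within 68% to 96%, an expected step of a number 2 percentage points lower from compound 1 to compound 4 (within the scatter).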

Compound 4, a percentage reported as activity, at one concentration (the size of the read-out at that concentration, not a potency): 78%
For compound 4 the middle estimate is 4 percentage points above the measured one, within the range that was stated.
By their numbers in this assay, from the lowest: compound 3; then compounds 4, 1 and 2 (each within the scatter of the next).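

In this assay, within the data shown here, the new step is the first to touch this position: going from ethoxy to methoxy, with hydrogen in place of methyl on a saturated chain carbon bound to an oxygen on an aromatic ring, gives a number 6 percentage points lower from compound 1 to compound 4 (within the scatter). Among these compounds, the earlier single-place step, a number 3 percentage points higher from compound 1 to compound 2 (within the scatter), showed only that a change elsewhere in the molecule stayed within the scatter, whereas this result shows the same for a one-carbon shortening at this position. No available evidence bears on this result.

The compounds shown leave open whether a longer chain such as propoxy, or a hydroxy group, at this position would also stay within the scatter. Among the compounds shown here, they also leave open which of its several differences sets compound 3 at 42%, as no single step links it to compound 1 or compound 4.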